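The compounds below may be only part of what the source reports. "The series", "measured", "known", "first", "only" and "open" are said of these compounds alone.

Three compounds share one core and differ only in the group carried on an aromatic nitrogen. Compound 1 `COc1ccc(-n2cc(CNCCN3CCN(C)CC3)c(-c3ccccc3C)n2)cc1` bears a 4-methoxyphenyl there, compound 2 `Cc1ccccc1-c1nn(-c2ccc(F)c(F)c2)cc1CNCCN1CCN(C)CC1` a 3,4-difluorophenyl, and compound 3 `CCOC(=O)Cn1cc(CNCCN2CCN(C)CC2)c(-c2ccccc2C)n1` an (ethoxycarbonyl)methyl. In an ADME assay on Huh-7 cells (Homo sapiens) for cytotoxicity (on this read-out higher numbers stand for lower toxicity in this test and lower numbers for higher toxicity in this test), compound 1 gives > 20000 nM, which is a limit of the assay rather than a number. In this assay compound 2 gives > 20000 nM, again a limit. Compound 3 gives > 20000 nM in this assay, also a limit. All of the evidence shown thus rests on (the limit of > 20000 nM in this assay, at which 3 of the 3 values shown sit). The steps a step that the two limits leave unreadable from compound 1 to compound 2, a step that the two limits leave unreadable from compound 1 to compound 3 and a step that the two limits leave unreadable from compound 2 to compound 3 therefore cannot be given a size.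

Compound 4 `Cc1ccccc1-c1nn(-c2cccc(C(F)(F)F)c2)cc1CNCCN1CCN(C)CC1` differs from compound 3 by 3-(trifluoromethyl)phenyl in place of (ethoxycarbonyl)methyl on an aromatic nitrogen. The measured steps bear on this change only in that every exchange so far at this aromatic nitrogen, aryl or ester-bearing chain alike, has left the read-out at the limit. Because the three values shown sit at the limit of > 20000 nM in this assay, at which 3 of the 3 values shown sit, the step from compound 3 to compound 4 is expected to bring no change beyond the scatter, a number no higher from compound 3 to compound 4 (the limit leaves the size open). In this assay compound 4 is estimated at 20000 nM, with a range from 10000 nM to 40000 nM.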

Compound 4, half-maximal cytotoxic concentration: 18000 nM
Estimate against measurement, compound 4: 1.1-fold (0.05 log units) above, within the range that was stated.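

In this assay, within the data shown here, compound 4 gives 18000 nM, the first value at this aromatic nitrogen that is a number rather than a limit, so the position now has one fixed point on the scale. Going by these compounds, the exchange for 3-(trifluoromethyl)phenyl reads as an at least 1.1-fold lower number from compound 3 to compound 4 (0.04 log units; that floor lies within the scatter), as an at least 1.1-fold lower number from compound 2 to compound 4 (0.04 log units; that floor lies within the scatter) and as an at least 1.1-fold lower number from compound 1 to compound 4 (0.04 log units; that floor lies within the scatter); each of these is only a floor, so the change from the ester-bearing chain or from either of the other aryl groups is established as a direction of no readable size, and its true size stays open. The rest of the set still rests on a single limit: the limit of > 20000 nM in this assay, at which 3 of the 4 values shown sit.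

On these data alone, the steps among compound 1, compound 2 and compound 3 cannot be read, so the order of these three relative to one another, and how far each lies from compound 4, stays unknown. Also open, as far as these compounds go, is whether an amine or a carboxylic acid on this aromatic nitrogen, or a longer chain carrying the ester, would give a number that stands clearly apart from that of compound 4.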